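Adding a Methoxy Group to Compound 2

The source may hold more compounds than are shown below. What is called first, only, known or untested is meant among the compounds shown, and "the series" means these compounds.

In a functional assay on MCF7 cells (Homo sapiens) for antiproliferative activity, read by MTT assay, with a stated time of 48 h (on this read-out higher numbers stand for weaker inhibition and lower numbers for stronger inhibition), compound 1 (`COc1ccc(-c2nnc(NC(=O)/C=C/c3ccc(C)cc3)s2)cc1`) gives 0.31 ug/mL while compound 2 (`O=C(/C=C/c1ccccc1)Nc1nnc(-c2ccccc2)s1`) gives 1.47 ug/mL as its reading. Compound 2 therefore holds the higher of the two numbers, and its gap to compound 1 lies beyond the usual scatter, which makes it the weaker inhibitor of the pair. Compound 3 (`COc1ccc(-c2nnc(NC(=O)/C=C/c3ccccc3)s2)cc1`) comes from compound 2 by a single change, methoxy in place of hydrogen on an aromatic carbon, which turns phenyl into 4-methoxyphenyl. Within the data shown here, no two measured compounds differ in one place, so the data offer no direct measure of this change. In this assay, among the measured compounds shown here, a lower number is expected for compound 3 than for compound 2, because compound 1 stands at 0.31 ug/mL and that is the only lower reading available. The estimated change is a 2.1-fold lower number from compound 2 to compound 3 (0.32 log units; beyond the scatter) and so a modest one, near the edge of the scatter. Compound 3 is estimated at 0.7 ug/mL within an expected range running from 0.3 ug/mL to 1.6 ug/mL on this read-out.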

Compound 3, half-maximal inhibitory concentration: 0.78 ug/mL
Compound 3: the middle estimate sits 1.1-fold (0.05 log units) below what was measured; low and high end bracket the measured number.
By their numbers in this assay, from the lowest: compound 1; then compounds 3 and 2 (each within the scatter of the next).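

Among these compounds, this is the first direct measure of methoxy in place of hydrogen on an aromatic carbon, para to a large group: in this assay the change from phenyl to 4-methoxyphenyl gives a 1.9-fold lower number from compound 2 to compound 3 (0.28 log units; within the scatter), so on this read-out the methoxy group alone cannot be told apart from no change at all. The same compound also isolates a second single change, on a different part of the structure, since hydrogen in place of methyl on an aromatic carbon gives a 2.5-fold higher number from compound 1 to compound 3 (0.40 log units; beyond the scatter), and this step, unlike the methoxy step, clears the scatter, so the methyl group that sets compound 1 apart from compound 3 makes a readable difference in the 4-methoxyphenyl series. Nothing available here bears on what lies behind either of these two steps.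

From the compounds shown here alone, whether a hydroxy group, a chlorine atom or an amine on this same aromatic carbon would give a step beyond the scatter remains open. Going by these compounds, it is also open whether the methyl step seen with 4-methoxyphenyl would hold on the plain phenyl of compound 2.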